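Ester variation on the shared core: cytotoxicity notes

This account rests on a few compounds, and the source may have more. Where it says the series, first, only, none or still open, it means among the compounds named here.

Measured compounds:
- compound 1, `O=C(O)CCCC(=O)OCCc1c(-c2ccccc2Cl)c2cc(Cl)ccc2[nH]c1=O`: 110000 nM
- compound 2, `O=C(OCCc1c(-c2ccccc2Cl)c2cc(Cl)ccc2[nH]c1=O)C1CCCC1`: 46000 nM
- compound 3, `O=C(OCCc1c(-c2ccccc2Cl)c2cc(Cl)ccc2[nH]c1=O)c1ccc([N+](=O)[O-])cc1`: 1600000 nM

In an ADME assay on HepG2 2.2.15 cells (Homo sapiens) for cytotoxicity (a lower number here means that less compound is tolerated, a higher number that more compound is tolerated), compound 3 gives the highest number of the three, standing a 15-fold higher number from compound 1 to compound 3 (1.16 log units; beyond the scatter) and a 35-fold higher number from compound 2 to compound 3 (1.54 log units; beyond the scatter). Among the measured esters it is the only one with an aromatic ring attached directly to the carbonyl carbon; compounds 1 and 2 carry open-chain or saturated groups there, and both sit well lower.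

The next compound, compound 4 `O=C(/C=C/c1ccc(C(F)(F)F)cc1)OCCc1c(-c2ccccc2Cl)c2cc(Cl)ccc2[nH]c1=O`, keeps the shared core and the ester linkage and changes the acyl part: 2-(4-(trifluoromethyl)phenyl)ethenyl in place of 4-nitrophenyl on a carbonyl carbon

Both measured steps that touch compound 3 bear on this change, as each replaces the group on the carbonyl carbon and each was large in this assay. Within the data shown here, no measured pair shows an ethenyl-linked aryl group or a trifluoromethyl group, so the direction is not fixed by precedent. Given that the only aromatic acyl group measured, compound 3 at 1600000 nM, gives the highest number, and that moving away from it has so far meant lower numbers, a step downward is expected for compound 4, of moderate size: a 4.6-fold lower number from compound 3 to compound 4 (0.66 log units; beyond the scatter). The estimate for compound 4 is 350000 nM, within 70000 nM to 1600000 nM.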

Compound 4, half-maximal cytotoxic concentration: > 1400000 nM
Compound 4: a limit, no number (the forecaster's own chance of this, stated with the estimate: 20%); middle value at least 4.0-fold (0.60 log units) away from the limit.
By their numbers in this assay, from the lowest: compound 2; then compound 1; then compound 3.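

In this assay compound 4 gives a limit and not a number: the limit of > 1400000 nM in this assay, at which 1 of the 4 values shown sits. The step from compound 3 cannot be read, so no order between these two esters can be stated, but the change from the saturated acyl groups reads as an at least 30-fold higher number from compound 2 to compound 4 (1.48 log units; beyond the scatter), and the change from the carboxylic acid-bearing chain reads as an at least 12-fold higher number from compound 1 to compound 4 (1.10 log units; beyond the scatter). Among these four esters, the two with an aromatic ring in the acyl part, compound 3 and compound 4, both sit well clear of compound 1 and compound 2, with no listed compound going against this, and the high end of the series is no longer tied to 4-nitrophenyl or to a ring attached directly to the carbonyl carbon.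

On these data alone, what the ethenyl link and the trifluoromethyl group each contribute stays open, since compound 4 brings in both at once and its limit gives no size for the change from compound 3. Also open, as far as these compounds go, is how a plain phenyl, a pyridine ring, or an amine on the acyl part would read at this position, and whether an amide linkage in place of the ester would keep compound 4's standing over compound 1 and compound 2.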